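Swapping a difluorophenyl amide for a pyridyl amide

A few compounds are considered here, and "the series" means these few. Any claim that something is new, unique, unknown or untested is made for them only; others in the source may bear on it.

Measured compounds:
- Compound 1, `CN1CCC(C(=O)N2Cc3c(NC(=O)c4cc(F)cc(F)c4)n[nH]c3C2(C)C)CC1`: 130 nM
- Compound 2, `CN1CCC(C(=O)Nc2n[nH]c3c2CN(C(=O)C(C)(C)C)C3(C)C)CC1`: 350 nM
- Compound 3, `CN1CCN(C(=O)N2Cc3c(NC(=O)c4ccc(F)cc4)n[nH]c3C2(C)C)CC1`: 180 nM

In a functional assay on A2780 cells (Homo sapiens) for antiproliferative activity, read by fluorescence, with a stated time of 72 h (on this read-out higher numbers stand for weaker inhibition and lower numbers for stronger inhibition), compound 1 gives the lowest number of the three. Compound 3 sits within the usual scatter of it, so the two cannot be ordered; compound 2 lies beyond the scatter with a higher number, and compound 2 also carries a different acyl group on the shared core, so no single change links it to the others.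

Compound 4, `CN1CCC(C(=O)N2Cc3c(NC(=O)c4ccncc4)n[nH]c3C2(C)C)CC1`, has not yet been measured in this assay. It differs from compound 1 in one place: pyridin-4-yl in place of 3,5-difluorophenyl on a carbonyl carbon. Among the compounds with values here, no pair of measured compounds shows this particular exchange, so its effect has to be judged without a precedent in the set. Since the three measured values all fall within a fairly narrow band despite differing acyl groups, a small step is expected, if anything toward a higher number. Compound 4 is therefore estimated at 250 nM, with a range from 90 nM to 700 nM, meaning an expected step of a 1.9-fold higher number from compound 1 to compound 4 (0.28 log units; within the scatter) that may not exceed the scatter.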

Compound 4, half-maximal inhibitory concentration: 500 nM
Estimate against measurement, compound 4: 2.0-fold (0.30 log units) below; the range from low to high includes it.
By their numbers in this assay, from the lowest: compounds 1, 3, 2 and 4 (each within the scatter of the next, the first and the last beyond it).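

In this assay, within the data shown here, the exchange of 3,5-difluorophenyl for pyridin-4-yl on a carbonyl carbon gives the first step in this set that can be read across a single change: a 3.8-fold higher number from compound 1 to compound 4 (0.59 log units; beyond the scatter). This position is therefore not indifferent to the aromatic ring it carries, since a carbon-only ring with 0 hydrogen-bond acceptors leaves, a ring with 1 hetero atom and 1 hydrogen-bond acceptor enters, and the number moves beyond the scatter. No measurement at hand speaks to why the number rises.

The compounds shown leave open whether the step goes with the loss of the two fluorine atoms or with the entry of the ring nitrogen, as both arrive in one exchange. A plain phenyl or a pyridin-3-yl on the same carbonyl carbon would tell these apart.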